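A few compounds are considered here, and "the series" means these few. Any claim that something is new, unique, unknown or untested is made for them only; others in the source may bear on it.

Working notes on the series.

Compound 1 `Nc1nc2c(s1)CC(CNC(=O)c1ccc[nH]1)CC2` is the parent. In an assay with sodium channel protein type 4 subunit alpha (Homo sapiens) as the target, read by patch clamp (a higher number here means a weaker inhibitor, a lower number a stronger inhibitor), compound 1 gives only a limit, > 30000 nM. Compound 2 `Nc1nc2c(s1)CC(CNC(=O)c1cc(Br)c[nH]1)CC2` carries the change (bromo in place of hydrogen on an aromatic carbon). In this assay compound 2 likewise gives only a limit, > 30000 nM. The step that the two limits leave unreadable from compound 1 to compound 2 therefore cannot be read in size. Compound 3 `Nc1nc2c(s1)C[C@@H](NC(=O)c1cc(Br)c[nH]1)CC2` has a different core; how the two cores differ is not broken down here. In this assay compound 3 also gives only a limit, > 30000 nM. All that is known of the measured set is the limit of > 30000 nM in this assay, at which 3 of the 3 values shown sit.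

Compound 4 `Nc1nc2c(s1)C[C@@H](NC(=O)c1cc(Br)c(Br)[nH]1)CC2` is not yet measured. It differs from compound 3 by bromo in place of hydrogen on an aromatic carbon. This is the same kind of change as in compound 1 to compound 2, but the place differs: there the bromo enters two ring bonds from the ring nitrogen, here it enters next to the ring nitrogen and next to the ring atom that bears a bromo group. Since every value shown sits at the limit, the step that the limit leaves unreadable from compound 3 to compound 4 is expected to be unreadable as well. For compound 4 the expected value in this assay is 40000 nM, most likely again reported as a limit.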

Compound 4, half-maximal inhibitory concentration: 15000 nM
Compound 4: middle estimate off by 2.7-fold (0.43 log units), on the high side; low and high end bracket the measured number.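

In this assay, as far as these compounds go, the new step reads an at least 2.0-fold lower number from compound 3 to compound 4 (0.30 log units; that floor lies within the scatter), so its true size stays unknown and it may be no more than scatter. Compound 4 is the only compound shown with a value that is not a limit, and the other three all sit at the same limit: the limit of > 30000 nM in this assay, at which 3 of the 4 values shown sit. The same kind of change on the core of compound 1 gives a step that cannot be read, and the bromo enters at a different place there, so these compounds show neither that the change carries from one core to the other nor that it fails to.

Open, from the compounds shown here alone, is whether a bromo next to the ring nitrogen on the core of compound 1 would also give a value that is not a limit, which would separate the effect of the place from that of the core. Open too, going by these compounds, is whether chloro, methyl or a carboxylic acid in that place would give a readable value in this assay.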